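Replacing the silicon group of compound 1 with 3-methyl-1,2-oxazol-5-yl

This account rests on a few compounds, and the source may have more. Where it says the series, first, only, none or still open, it means among the compounds named here.

Among the measured compounds shown here, in a functional assay on U-373MG ATCC cells for inhibition, with U373 MG (Homo sapiens) as the target, read by MTT assay, with a stated time of 7 days (a higher number here means a weaker inhibitor of growth, a lower number a stronger inhibitor of growth), compound 1 (`C[Si](C)(C)Cn1nnc2c(C(N)=O)ncn2c1=O`) gives 45600 nM as the only true number among the three compounds measured. Compound 2 (`NC(=O)c1ncn2c(=O)n(Cc3ccccc3)nnc12`) reads > 50000 nM and this is a limit of the assay, not a number. Compound 3 (`COc1ccc(Cn2nnc3c(C(N)=O)ncn3c2=O)c(OC)c1`) reads > 50000 nM and this too is a limit, not a number. The series is thus dominated by the limit of > 50000 nM in this assay, at which 2 of the 3 values shown sit, and compound 1 is the only starting point with a number.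

Compound 4 (`Cc1cc(Cn2nnc3c(C(N)=O)ncn3c2=O)on1`) has not yet been measured. Its change from compound 1 is a group of 6 heavy atoms (4 carbon, 1 nitrogen, 1 oxygen; one five-membered aromatic ring with 2 hetero atoms) in place of a group of 4 heavy atoms (3 carbon, 1 silicon; no ring), on a saturated chain carbon bound to an aromatic nitrogen and the entering group, 3-methyl-1,2-oxazol-5-yl, sits on a saturated chain carbon bound to an aromatic nitrogen.

The nearest measured step is an at least 1.0-fold higher number from compound 1 to compound 2 (0.04 log units; that floor lies within the scatter) and there a six-membered aromatic ring of carbon only enters at that same place. Given an at least 1.0-fold higher number from compound 1 to compound 2 (0.04 log units; that floor lies within the scatter) as the only measured guide, no step beyond the scatter is expected in this assay for compound 4. The estimated step is a 1.2-fold higher number from compound 1 to compound 4 (0.08 log units; within the scatter) and it is not expected to be a real change. Compound 4 is expected at 55000 nM within an estimated range from 30000 nM to 100000 nM.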

Compound 4, concentration for 50% growth inhibition: > 50000 nM
Compound 4: no number, only a limit; the forecaster's own chance of this, stated with the estimate: 65%; the middle value does not contradict the limit.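

In this assay, placing 3-methyl-1,2-oxazol-5-yl on a saturated chain carbon bound to an aromatic nitrogen gives an at least 1.0-fold higher number from compound 1 to compound 4 (0.04 log units; that floor lies within the scatter), so a ring with hetero atoms, like the carbon-only ring of compound 2, yields no number at this place, and the floor of that step shows no real change while leaving room for a larger one. Compound 4 reads > 50000 nM, which is a limit of the assay and not a number. Compound 1 therefore remains the only compound with a number, and the series now rests even more heavily on a single ceiling: the limit of > 50000 nM in this assay, at which 3 of the 4 values shown sit.

The step from compound 2 to compound 4 cannot be read, so the compounds shown do not tell how 3-methyl-1,2-oxazol-5-yl and phenyl compare at this place. On these data alone, it also stays open whether an amine, a carboxylic acid or the all-carbon counterpart of the silicon group at this position would give a number in this assay, and whether any such number would differ from that of compound 1 by more than the scatter.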